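Adding a second fluorine to the ring on the nitrogen

The source may report more compounds than this note shows. Statements on the series, on what has been measured and on what is new or still open speak of the compounds shown alone.

Of the compounds shown here, two of one shared core have been measured in a functional assay on PC-12 cells (Rattus norvegicus) for cytotoxicity, read by MTT assay, with stated times of 2 h and 24 h, tested at 5 uM; a higher number here means a stronger effect of the compound at the concentration tested, a lower number a weaker effect. Compound 1, with structure `CCc1ccc(-n2nc(-c3ccc(C(F)(F)F)cc3O)nc2-c2ccccc2O)cc1`, gives 95.4% in this assay. Compound 2, with structure `Oc1cc(C(F)(F)F)ccc1-c1nc(-c2ccccc2O)n(-c2ccccc2F)n1`, gives 86.6% in this assay. Among the measured compounds shown here, the only measured step, a number 8.8 percentage points lower from compound 1 to compound 2 (within the scatter), leaves the read-out where it was, so compound 2 stands on the lower of two numbers that cannot be told apart.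

Compound 3, with structure `Oc1cc(C(F)(F)F)ccc1-c1nc(-c2ccccc2O)n(-c2ccc(F)cc2F)n1`, is the unmeasured compound. The change from compound 2 to compound 3 is fluoro in place of hydrogen on an aromatic carbon, so the ring on the aromatic nitrogen goes from 2-fluorophenyl to 2,4-difluorophenyl.

For the measured compounds named here, the one step that bears on this is the swap of the whole ring on that nitrogen from compound 1 to compound 2, which stayed within the scatter. A single added fluoro on the same ring is a smaller change than that swap, so no step beyond the scatter is expected in this assay, with a number 0.4 percentage points higher from compound 2 to compound 3 (within the scatter) as the expected step. Compound 3 is therefore estimated at 87%, between 72% and 98%.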

Compound 3, a percentage reported as activity, at one concentration (the size of the read-out at that concentration, not a potency): 83.5%
Compound 3: the middle estimate sits 3.5 percentage points above what was measured, and the stated range covers the measured number.
By their numbers in this assay, from the lowest: compounds 3, 2 and 1 (each within the scatter of the next, the first and the last beyond it).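

In this assay the fluoro placed on this aromatic carbon, para to a large group and meta to a fluoro group, gives a number 3.1 percentage points lower from compound 2 to compound 3 (within the scatter) and so leaves the read-out indistinguishable from that of the 2-fluorophenyl ring. Seen against the 4-ethylphenyl ring, however, the 2,4-difluorophenyl ring gives a number 11.9 percentage points lower from compound 1 to compound 3 (beyond the scatter) as the first step among these compounds to pass beyond the usual scatter, although it is only a modest one, and the 2-fluorophenyl ring, compound 2, sits within the scatter of both neighbours, so the three compounds form a shallow slope rather than two separate levels. Nothing available here explains why the two rings on the nitrogen differ in this way.

The compounds shown leave open whether this same ring carbon would tolerate something other than fluoro, such as a methoxy group, an amine or a carboxylic acid, with the read-out staying in the same range. They also leave open how a longer chain, such as butyl in the place of the ethyl of compound 1, would compare, and each reading here comes from a single concentration, so it says nothing about potency.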